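The source may hold more compounds than are shown below. What is called first, only, known or untested is meant among the compounds shown, and "the series" means these compounds.

Measured so far:
compound 1, `O=C(/C=C/c1ccc(OCc2nc(C3CCN(Cc4cccc(F)c4)CC3)no2)cc1)NO` — in an assay on isolated protein for inhibition of protein deacetylase HDAC6 (Homo sapiens), read by fluorescence, with a stated time of 1 h, tested at 100 nM (on this read-out lower numbers stand for less inhibition and higher numbers for more inhibition at the one concentration tested (going by the name of the read-out)), compound 1 gives 73%.
compound 2, `O=C(/C=C/c1ccc(OCc2nc(C3CCN(Cc4ccc(F)cc4F)CC3)no2)cc1)NO` — in this assay compound 2 gives 74%.

Compound 2 carries the larger of the two numbers shown, yet a number 1 percentage points higher from compound 1 to compound 2 (within the scatter) lies within the scatter, so the two are level. Compound 3, `O=C(/C=C/c1ccc(OCc2nc(C3CCN(Cc4ccccc4Cl)CC3)no2)cc1)NO`, is not yet measured. (2-chlorophenyl in place of 2,4-difluorophenyl on a saturated chain carbon bound to an amine nitrogen in a ring). Among the compounds with values here, the single measured step that bears on this change, a number 1 percentage points higher from compound 1 to compound 2 (within the scatter), swapped the fluorine pattern at the same place and stayed within the scatter. No movement beyond the scatter in this assay is therefore expected; the expected step is a number 2 percentage points lower from compound 2 to compound 3 (within the scatter). Compound 3 is estimated at 72%, with a range from 58% to 84%.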

Compound 3, a percentage reported as inhibition, at one concentration (the size of the read-out at that concentration, not a potency): 59%
Estimate against measurement, compound 3: 13 percentage points above; the range from low to high includes it.
By their numbers in this assay, from the lowest: compound 3; then compounds 1 and 2 (each within the scatter of the next).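

In this assay, the place on a saturated chain carbon bound to an amine nitrogen in a ring proves sensitive to the aromatic group it carries. 2-Chlorophenyl gives a number 15 percentage points lower from compound 2 to compound 3 (beyond the scatter) and also a number 14 percentage points lower from compound 1 to compound 3 (beyond the scatter), whereas the two fluorinated groups gave values within the scatter of each other. No evidence is at hand to account for this drop.

The compounds shown leave open whether the drop follows from chlorine itself or from where it sits, a question that 3-chlorophenyl and 2-fluorophenyl would separate. Going by these compounds, how unsubstituted phenyl would fare at this place also remains open.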